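Keto amide series: extending the benzyl group of compound 3

This account rests on a few compounds, and the source may have more. Where it says the series, first, only, none or still open, it means among the compounds named here.

Values in a functional assay for inhibition, with Rattus norvegicus as the target, at pH 7.35; on this read-out higher numbers stand for weaker inhibition and lower numbers for stronger inhibition:
- compound 1 `CCC(NC(=O)C(CC(C)C)NC(=O)OCc1ccccc1)C(=O)C(=O)OC`: 280000 nM
- compound 2 `CCCCCCCCNC(=O)C(=O)C(CC)NC(=O)C(CC(C)C)NC(=O)OCc1ccccc1`: 200000 nM
- compound 3 `CCC(NC(=O)C(CC(C)C)NC(=O)OCc1ccccc1)C(=O)C(=O)NCc1ccccc1`: 50000 nM
- compound 4 `CCC(NC(=O)C(CC(C)C)NC(=O)OCc1ccccc1)C(=O)C(=O)NCCCc1ccccc1`: not yet measured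

Compound 3 has the lowest number of the three, and its gaps to both others lie beyond the scatter. The next change gives compound 4, with phenethyl in place of phenyl on a saturated chain carbon bound to an amide-type nitrogen. Cut one bond further out, this reads benzyl to 3-phenylpropyl.

Among the compounds with values here, three measured steps bear on it. Benzylamino in place of methoxy gave a 5.6-fold lower number from compound 1 to compound 3 (0.75 log units; beyond the scatter), while octylamino in the same place gave only a 1.4-fold lower number from compound 1 to compound 2 (0.15 log units; within the scatter). Phenyl in place of heptyl gave a 4.0-fold lower number from compound 2 to compound 3 (0.60 log units; beyond the scatter). These steps are modest at most, and none tests a phenyl-bearing chain of another length. Compound 4 keeps the phenyl, so only a small change is expected in this assay, most likely within the scatter and towards a lower number.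

The expected step is a 1.4-fold lower number from compound 3 to compound 4 (0.15 log units; within the scatter). For compound 4 the estimate is 35000 nM, with an expected range of 10000 nM to 120000 nM.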

Compound 4, half-maximal inhibitory concentration: 100000 nM
Compound 4: middle estimate off by 2.9-fold (0.46 log units), on the low side; the measured number falls inside the stated range.
By their numbers in this assay, from the lowest: compounds 3, 4, 2 and 1 (each within the scatter of the next, the first and the last beyond it).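

In this assay, benzyl to 3-phenylpropyl gives a 2.0-fold higher number from compound 3 to compound 4 (0.30 log units; within the scatter), the first test of the length of a phenyl-bearing chain, and it shows no change that can be separated from the scatter. Phenyl in place of pentyl on a saturated chain carbon, three bonds along the chain from an amide-type nitrogen, gives a 2.0-fold lower number from compound 2 to compound 4 (0.30 log units; within the scatter), whereas phenyl in place of heptyl gave a 4.0-fold lower number from compound 2 to compound 3 (0.60 log units; beyond the scatter), so the clear gap from the octylamino compound is seen only for the benzyl group. (3-Phenylpropyl)amino in place of methoxy gives a 2.8-fold lower number from compound 1 to compound 4 (0.45 log units; beyond the scatter), which keeps compound 4 clear of the methyl ester.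

Nothing available accounts for the size of these steps. As far as these compounds go, whether a 5-phenylpentyl chain, or a carboxylic acid at the end of the chain, would move the number beyond the scatter from compound 3 remains open.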